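Hydroxymethyl Replaces Methanesulfonamido on the Fused Ring

The source may report more compounds than this note shows. Statements on the series, on what has been measured and on what is new or still open speak of the compounds shown alone.

Two compounds sharing one core have been characterised in an ADME assay on the whole organism (plasma, Macaca fascicularis) for protein binding, read by LC-MS, using equilibrium dialysis and cassette dosing, with a stated time of 24 h, at a dose of 1 mg/kg by the oral route; a lower number here means a smaller unbound share, a higher number a larger unbound share of the compound. Compound 1 `CCCCN(c1nc2c(C(=O)O)cccc2o1)[C@H](C)c1ccc(-c2ccccc2-c2nnn[nH]2)cc1` gives 0.000285 in this assay. Compound 2 `CCCCN(c1nc2c(NS(C)(=O)=O)cccc2o1)[C@H](C)c1ccc(-c2ccccc2-c2nnn[nH]2)cc1` gives 0.000203 in this assay, and among the two numbers it stands as the lowest, with compound 1 as its nearest neighbour. For the measured compounds named here, the only step measured between them, a 1.4-fold lower number from compound 1 to compound 2 (0.15 log units; within the scatter), lies within the scatter, so the two compounds cannot be told apart in this assay.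

Compound 3 `CCCCN(c1nc2c(CO)cccc2o1)[C@H](C)c1ccc(-c2ccccc2-c2nnn[nH]2)cc1` has not yet been measured. It differs from compound 2 in one place: hydroxymethyl in place of methanesulfonamido on an aromatic carbon. Going by the values given here, the one measured step bears on it only loosely, since it swapped carboxy for methanesulfonamido at the same place and produced no change beyond the scatter. Hydroxymethyl is a third group at that place, and no step in the data involves it. The expectation is therefore a step of a 1.1-fold lower number from compound 2 to compound 3 (0.05 log units; within the scatter), not beyond the scatter in either direction. Compound 3 is expected to give about 0.00018 in this assay, with a range from 0.00006 to 0.00055.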

Compound 3, unbound fraction: 0.00112
The estimate for compound 3 lay 6.2-fold (0.79 log units) below the measured number; measured number outside the range, above it.
By their numbers in this assay, from the lowest: compounds 2 and 1 (each within the scatter of the next); then compound 3.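

In this assay this place on the aromatic ring is not indifferent to the group it carries: the earlier pair showed no change beyond the scatter, but hydroxymethyl in place of methanesulfonamido gives a 5.5-fold higher number from compound 2 to compound 3 (0.74 log units; beyond the scatter) and hydroxymethyl in place of carboxy gives a 3.9-fold higher number from compound 1 to compound 3 (0.59 log units; beyond the scatter) with both steps beyond the scatter. Compound 3 therefore stands apart from compound 1 and compound 2, which remain within the scatter of each other, and it has the largest unbound share of the three, so a change at this place can shift the number even though the swap between the two earlier groups did not. Nothing available here accounts for the size or direction of this change.

The three compounds do not show whether the shift belongs to the hydroxyl of the new group or to its carbon, a question that a methoxymethyl or a plain methyl group at this place would address. Nor do they show how an amine, a primary amide or a longer hydroxyalkyl chain would stand at this place, or whether the shift would hold with the butyl chain of the shared core replaced.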